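The compounds below may be only part of what the source reports. "The series", "measured", "known", "first", "only" and "open" are said of these compounds alone.

Values in a functional assay on FM3A cells (Mus musculus) for antiproliferative activity; on this read-out lower numbers stand for stronger inhibition and higher numbers for weaker inhibition:
Compound 1 `COc1cc(C(=O)c2sc(-c3ccc(I)cc3)cc2N)cc(OC)c1OC`: 420 nM
Compound 2 `COc1cc(C(=O)c2sc(-c3ccccc3)cc2N)cc(OC)c1OC`: 13 nM
Compound 3 `COc1cccc(-c2cc(N)c(C(=O)c3cc(OC)c(OC)c(OC)c3)s2)c1`: 36 nM

Among these three numbers, compound 3 stands second highest, with compound 2 lower and compound 1 higher. The next change leads from compound 3 to compound 4 `COc1cc(C(=O)c2sc(-c3cccs3)cc2N)cc(OC)c1OC`. It puts thiophen-2-yl in place of 3-methoxyphenyl on an aromatic carbon next to the ring sulfur (thiophen-2-yl in place of 3-methoxyphenyl on an aromatic carbon).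

For the measured compounds named here, three measured steps bear on this, all at the same place on the shared core. Hydrogen in place of iodo gave a large step, a 32-fold lower number from compound 1 to compound 2 (1.51 log units; beyond the scatter). Swapping 4-iodophenyl for 3-methoxyphenyl was also large, a 12-fold lower number from compound 1 to compound 3 (1.07 log units; beyond the scatter). Adding methoxy was only modest, a 2.8-fold higher number from compound 2 to compound 3 (0.44 log units; beyond the scatter).

Both large steps remove iodo, and compound 4 carries none. Going by the values given here, no measured compound has a five-membered ring at this place, so the guide is indirect. The closest references are compound 2 at 13 nM and compound 3 at 36 nM. In this assay, no step beyond the scatter is therefore expected. The expected change is a 1.2-fold lower number from compound 3 to compound 4 (0.08 log units; within the scatter). Compound 4 is estimated at 30 nM, with an expected range of 10 nM to 110 nM.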

Compound 4, half-maximal inhibitory concentration: 1.7 nM
Beside the measured number, compound 4's estimate is 18-fold (1.25 log units) above it; the whole stated range lies above it.
By their numbers in this assay, from the lowest: compound 4; then compound 2; then compound 3; then compound 1.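

In this assay, the group at this place can do more than hold the level set by the phenyl of compound 2: thiophen-2-yl gives the lowest number of the four (a 7.6-fold lower number from compound 2 to compound 4 (0.88 log units; beyond the scatter)), with larger steps against the other two (a 21-fold lower number from compound 3 to compound 4 (1.33 log units; beyond the scatter); a 250-fold lower number from compound 1 to compound 4 (2.39 log units; beyond the scatter)). Among the earlier compounds, both departures from phenyl raised the number, so compound 4 is the first to improve on it, and it does so with a five-membered aromatic ring with one sulfur. Nothing at hand explains this gain.

The compounds shown leave open whether the gain depends on the ring sulfur or on how the ring is attached, which furan-2-yl or thiophen-3-yl at this place would test. They also leave open whether a methyl or chloro group on the thiophen-2-yl ring would keep the number this low.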